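Swapping the aryl tail: from compound 3 to compound 4

A few compounds are considered here, and "the series" means these few. Any claim that something is new, unique, unknown or untested is made for them only; others in the source may bear on it.

Three compounds sharing one core and a three-carbon chain that ends in an aromatic ring were tested in a functional assay on 1321-N1 cells for agonist activity at P2Y purinoceptor 4 (Homo sapiens), read by scintillation counting and inositol phosphate accumulation; on this read-out higher numbers stand for an effect only at larger amounts of compound and lower numbers for an effect already at smaller amounts. Compound 1 `O=c1[nH]/c(=N\OCCCc2ccc(F)cc2)ccn1[C@@H]1O[C@H](COP(=O)(O)OP(=O)(O)OP(=O)(O)O)[C@@H](O)[C@H]1O` gives 105 nM, compound 2 `O=c1[nH]/c(=N\OCCCc2ccc(I)cc2)ccn1[C@@H]1O[C@H](COP(=O)(O)OP(=O)(O)OP(=O)(O)O)[C@@H](O)[C@H]1O` gives 91 nM, and compound 3 `COc1ccc(CCCO/N=c2/ccn([C@@H]3O[C@H](COP(=O)(O)OP(=O)(O)OP(=O)(O)O)[C@@H](O)[C@H]3O)c(=O)[nH]2)cc1` gives 23 nM. Compound 3 thus stands lowest of the three, and both steps to it lie beyond the scatter: a 4.6-fold lower number from compound 1 to compound 3 (0.66 log units; beyond the scatter) and a 4.0-fold lower number from compound 2 to compound 3 (0.60 log units; beyond the scatter), whereas a 1.2-fold lower number from compound 1 to compound 2 (0.06 log units; within the scatter). Compound 4 `O=c1[nH]/c(=N\OCCCc2ccncc2)ccn1[C@@H]1O[C@H](COP(=O)(O)OP(=O)(O)OP(=O)(O)O)[C@@H](O)[C@H]1O` has not been measured; it differs from compound 3 by pyridin-4-yl in place of 4-methoxyphenyl on a saturated chain carbon, three bonds along the chain from an oxygen on an unsaturated carbon. Among the measured compounds shown here, no measured step exchanges the whole ring, and none removes the methoxy group while keeping the ring; the two steps that touch this position only exchange one substituent for another, and both show the methoxy-bearing ring at the lowest number. The pyridyl ring of compound 4 carries no such substituent. Relative to compound 3, compound 4 is therefore expected to show a higher number, a step of a 2.6-fold higher number from compound 3 to compound 4 (0.42 log units; beyond the scatter). Compound 4 is estimated at 60 nM, within a range of 20 nM to 200 nM.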

Compound 4, half-maximal effective concentration: 250 nM
Compound 4: middle estimate off by 4.2-fold (0.62 log units), on the low side, outside the stated range (above it).
By their numbers in this assay, from the lowest: compound 3; then compounds 2 and 1 (each within the scatter of the next); then compound 4.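

In this assay, the ring at the end of the propyl chain can be exchanged as a whole, and this change moves the number further than either substituent exchange on the phenyl ring did, with an 11-fold higher number from compound 3 to compound 4 (1.04 log units; beyond the scatter). The pyridin-4-yl ring also stands apart from the 4-iodophenyl and 4-fluorophenyl rings, with a 2.7-fold higher number from compound 2 to compound 4 (0.44 log units; beyond the scatter) and a 2.4-fold higher number from compound 1 to compound 4 (0.38 log units; beyond the scatter), so each of the three substituted phenyl rings gives a lower number here than pyridin-4-yl. Nothing available accounts for the size of these steps.

The compounds shown leave open whether the rise follows from the ring nitrogen or from the loss of a substituent, which a plain phenyl ring on the same chain would separate. They also leave open whether a methoxypyridinyl ring would bring the number back down.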